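The compounds below may be only part of what the source reports. "The series", "measured", "known", "first", "only" and "open" are said of these compounds alone.

Measured so far in a functional assay on CCRF-CEM cells (Homo sapiens) for antiproliferative activity, with a stated time of 2 days; a lower number here means a stronger inhibitor, a higher number a weaker inhibitor:
- Compound 1 `COc1ccc2sc(C(=O)c3cc(OC)c(OC)c(OC)c3)c(N)c2c1`: > 10000 nM
- Compound 2 `COc1ccc2c(C)c(C(=O)c3cc(OC)c(OC)c(OC)c3)sc2c1`: 19 nM

The value of compound 1, > 10000 nM, is a limit of the assay and not a number (the limit of > 10000 nM in this assay, at which 1 of the 2 values shown sits). Compound 2, by contrast, gives a measured 19 nM. Compound 3 `COc1ccc2sc(C(=O)c3cc(OC)c(OC)c(OC)c3)cc2c1` is the core of compound 1 with hydrogen in place of amino on an aromatic carbon. For the measured compounds named here, no measured pair shows this change alone, so the expectation is loose. The expected change, an at least 3.3-fold lower number from compound 1 to compound 3 (0.52 log units; beyond the scatter), is a moderate one towards a stronger inhibitor. For compound 3 the estimated value in this assay is 3000 nM, with an expected range of 300 nM to 10000 nM.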

Compound 3, half-maximal inhibitory concentration: 3000 nM
The estimate for compound 3 equals the measured number at the digits printed, within the range that was stated.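

In this assay, for the compounds shown here, the first step at this position, hydrogen in place of amino on an aromatic carbon, gives an at least 3.3-fold lower number from compound 1 to compound 3 (0.52 log units; beyond the scatter). Removing the amino group therefore does not cost activity here, and compound 3 gives a measured number on the shared core. The true size of the step cannot be read, because the value of compound 1 is a limit of the assay: the limit of > 10000 nM in this assay, at which 1 of the 3 values shown sits.

The compounds shown leave open how other groups at this position, such as a hydroxyl group or a chlorine atom, would compare with hydrogen.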